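The source may report more compounds than this note shows. Statements on the series, on what has been measured and on what is new or still open speak of the compounds shown alone.

Compound 1 `CCOc1cc(C(C)(C)C)ccc1C1=NC(c2ccc(Cl)cc2)C(c2ccc(Cl)cc2)N1C(=O)N1CCN(Cc2ccc(C(=O)NO)cc2)CC1`: 2030 nM
Compound 2 `CCOc1cc(C(C)(C)C)ccc1C1=NC(c2ccc(Cl)cc2)C(c2ccc(Cl)cc2)N1C(=O)NCCCCCCCC(=O)NO`: 5030 nM

Both were tested in a functional assay on HCT-116 cells (Homo sapiens) for antiproliferative activity, read by CCK-8 assay, with a stated time of 72 h; a lower number here means a stronger inhibitor, a higher number a weaker inhibitor. Of the two numbers, compound 2 gives the higher one, while compound 1 sits at 2030 nM, a gap beyond the usual scatter. Compound 3 `CCOc1cc(C(C)(C)C)ccc1C1=NC(c2ccc(Cl)cc2)C(c2ccc(Cl)cc2)N1C(=O)NCCCCCC(=O)Nc1ccccc1N` has not yet been measured. It differs from compound 2 in one place: (2-aminophenyl)carbamoyl in place of 2-(hydroxycarbamoyl)ethyl on a saturated chain carbon, five bonds along the chain from an amide-type nitrogen. Going by the values given here, no measured pair here follows this change, so the step expected in this assay, a 1.2-fold higher number from compound 2 to compound 3 (0.08 log units; within the scatter), is taken as modest and uncertain, leaning slightly toward a higher number. Compound 3 is therefore estimated at 6000 nM, within a range from 1500 nM to 24000 nM.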

Compound 3, half-maximal inhibitory concentration: 21800 nM
Beside the measured number, compound 3's estimate is 3.6-fold (0.56 log units) below it; the measured number falls inside the stated range.
By their numbers in this assay, from the lowest: compound 1; then compound 2; then compound 3.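

In this assay, putting (2-aminophenyl)carbamoyl in place of 2-(hydroxycarbamoyl)ethyl on this saturated chain carbon gives a 4.3-fold higher number from compound 2 to compound 3 (0.64 log units; beyond the scatter), a step beyond the scatter. Going by these compounds alone, this is the first one-place comparison in the set, and it shows that the group at this chain end changes the antiproliferative reading, here for the worse. No measurement here bears on why the number rises. Still open, from the compounds shown here alone, is how a carboxylic acid at this chain end would read, and whether a longer chain carrying (2-aminophenyl)carbamoyl would shift the number.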